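This account rests on a few compounds, and the source may have more. Where it says the series, first, only, none or still open, it means among the compounds named here.

Measured so far in a functional assay on HepG2 cells (Homo sapiens) for antiproliferative activity, read by CCK-8 assay, with a stated time of 72 h; on this read-out higher numbers stand for weaker inhibition and lower numbers for stronger inhibition:
- Compound 1 `Nc1ccccc1NC(=O)c1ccc(COc2ccc([N+](=O)[O-])cc2)cc1`: > 32000 nM, a limit of the assay
- Compound 2 `Nc1ccccc1NC(=O)c1ccc(COc2ccccc2)cc1`: 6700 nM
- Compound 3 `CCc1ccc(OCc2ccc(C(=O)Nc3ccccc3N)cc2)cc1`: 6960 nM

Compound 3, at 6960 nM, lies within the scatter of compound 2, at 6700 nM. Within the data shown here, the only other compound in the set gives a limit rather than a number.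

Compound 4 `Nc1ccccc1NC(=O)c1ccc(COc2ccc(F)cc2)cc1` has not yet been measured in this assay. Its structure differs from that of compound 3 by fluoro in place of ethyl on an aromatic carbon, with fluoro in place of ethyl on an aromatic carbon.

Among the measured compounds shown here, three measured steps bear on this change. The closest is a 1.0-fold higher number from compound 2 to compound 3 (0.02 log units; within the scatter), which does not separate ethyl from hydrogen at this place. Nitro behaves differently, as shown by an at least 4.7-fold lower number from compound 1 to compound 2 (0.67 log units; beyond the scatter) and by an at least 4.5-fold lower number from compound 1 to compound 3 (0.66 log units; beyond the scatter), both beyond the scatter. Fluoro itself has not been tested here, so a shift cannot be ruled out, but with compound 2 and compound 3 so close, no step beyond the scatter is expected. The expected result is a 1.1-fold lower number from compound 3 to compound 4 (0.03 log units; within the scatter). For compound 4 the estimated value is 6500 nM, with an expected range of 3000 nM to 15000 nM.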

Compound 4, half-maximal inhibitory concentration: 3840 nM
For compound 4 the middle estimate is 1.7-fold (0.23 log units) above the measured one, within the range that was stated.
By their numbers in this assay, from the lowest: compounds 4, 2 and 3 (each within the scatter of the next). At a limit, above all of these: compound 1.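

In this assay, fluoro at this place, on an aromatic carbon para to a large group, cannot be told apart from either ethyl (a 1.8-fold lower number from compound 3 to compound 4 (0.26 log units; within the scatter)) or hydrogen (a 1.7-fold lower number from compound 2 to compound 4 (0.24 log units; within the scatter)). Fluoro therefore joins those two groups, and nitro remains the only group shown here that stands apart, now also against fluoro (an at least 8.3-fold lower number from compound 1 to compound 4 (0.92 log units; beyond the scatter)). Compound 1 gives a limit rather than a number, so this last step has no fixed size: the limit of > 32000 nM in this assay, at which 1 of the 4 values shown sits.

The compounds shown leave open how an amine, a carboxylic acid or a chain longer than ethyl would behave at this place, and whether chloro or methoxy would fall with fluoro or with nitro. As far as these compounds go, it also remains open whether fluoro would give the same result elsewhere on this ring.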